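Swapping a piperidine ester for a nitrophenyl ester

The source may report more compounds than this note shows. Statements on the series, on what has been measured and on what is new or still open speak of the compounds shown alone.

Measured compounds:
- compound 1 `C=C1C(=O)O[C@@H]2CC(C)=C([C@@H](C)CCCOC(C)=O)[C@@H](OC(=O)CN3CCCCC3)[C@H]12`: 10300 nM
- compound 2 `C=C1C(=O)O[C@@H]2CC(C)=C([C@@H](C)CCCOC(C)=O)[C@@H](OC(=O)COc3cccc(C(C)=O)c3)[C@H]12`: 38600 nM
- compound 3 `C=C1C(=O)O[C@@H]2CC(C)=C([C@@H](C)CCCOC(C)=O)[C@@H](OC(=O)c3cccc(F)c3)[C@H]12`: 11800 nM

All three share one core and differ only in the ester group attached to it. In a functional assay on HeLa cells (Homo sapiens) for cytotoxicity, read by sulforhodamine B assay, with a stated time of 72 h (a lower number here means a stronger inhibitor, a higher number a weaker inhibitor), compound 1 gives 10300 nM. This is at the lower end of the three numbers; compound 3 is within the scatter of it, and only compound 2 is clearly separated, with a 3.7-fold higher number from compound 1 to compound 2 (0.57 log units; beyond the scatter).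

Compound 4 `C=C1C(=O)O[C@@H]2CC(C)=C([C@@H](C)CCCOC(C)=O)[C@@H](OC(=O)c3ccc([N+](=O)[O-])cc3)[C@H]12` has not yet been measured. It differs from compound 1 as follows: 4-nitrophenyl in place of (piperidin-1-yl)methyl on a carbonyl carbon.

Among the measured compounds shown here, the step that bears most on this change is the one from compound 1 to compound 3, where an aromatic ring also replaced the (piperidin-1-yl)methyl group on the carbonyl carbon, giving a 1.1-fold higher number from compound 1 to compound 3 (0.06 log units; within the scatter). The step from compound 2 to compound 3, a 3.3-fold lower number from compound 2 to compound 3 (0.51 log units; beyond the scatter), shows that an aryl group bound directly to the carbonyl carbon did not weaken activity. For compound 4 the expected change is therefore a 1.2-fold higher number from compound 1 to compound 4 (0.07 log units; within the scatter), that is, no step beyond the scatter.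

The estimate for compound 4 in this assay is 12000 nM, with an expected range from 5000 nM to 30000 nM.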

Compound 4, half-maximal inhibitory concentration: 11300 nM
Beside the measured number, compound 4's estimate is 1.1-fold (0.03 log units) above it; the range from low to high includes it.
By their numbers in this assay, from the lowest: compounds 1, 4 and 3 (each within the scatter of the next); then compound 2.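

In this assay, a second aromatic group bound directly to this carbonyl carbon gives a 1.1-fold higher number from compound 1 to compound 4 (0.04 log units; within the scatter), so the earlier result with 3-fluorophenyl was not a one-off: 4-nitrophenyl can also stand in place of (piperidin-1-yl)methyl without a step beyond the scatter. The two aromatic esters cannot be told apart, with a 1.0-fold lower number from compound 3 to compound 4 (0.02 log units; within the scatter), even though the ring carries a different group in each. The gap to the (3-acetylphenoxy)methyl ester appears again, with a 3.4-fold lower number from compound 2 to compound 4 (0.53 log units; beyond the scatter), which leaves compound 2 as the only one of the four set clearly apart.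

Nothing available here gives a reason for these numbers. As far as these compounds go, it remains open whether a carboxylic acid or an amine in place of the nitro group, or a longer chain between the carbonyl carbon and the ring, would stay in this range.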